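Sigma receptor series: aryl-to-thienyl swap on the amine substituent

A few compounds are considered here, and "the series" means these few. Any claim that something is new, unique, unknown or untested is made for them only; others in the source may bear on it.

Within the data shown here, compound 2 `COc1ccc(CN2CCC3(CC2)OC(OC)Cc2sccc23)cc1` holds the higher of the two numbers measured so far in an assay on membranes from brain for displacement of a labelled ligand from Sigma non-opioid intracellular receptor 1 (Cavia porcellus); on this read-out lower numbers stand for stronger inhibition and higher numbers for weaker inhibition; compound 2 gives 2.2 nM. Among the measured compounds shown here, its nearest neighbour is compound 1 `COC1Cc2sccc2C2(CCN(CCC(C)C)CC2)O1`, which in this assay gives 1 nM; the step of a 2.2-fold higher number from compound 1 to compound 2 (0.34 log units; beyond the scatter) is the only measured step in the set, and it covers an exchange on the same chain carbon.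

The unmeasured compound 3 `COC1Cc2sccc2C2(CCN(Cc3cccs3)CC2)O1` differs from compound 2 by thiophen-2-yl in place of 4-methoxyphenyl on a saturated chain carbon bound to an amine nitrogen in a ring. For the measured compounds named here, no measured pair shows an aromatic ring being exchanged for another aromatic ring at this position; the one step on record, from an isobutyl chain to the methoxyphenyl group, was modest in size. Going by the values given here, with both the leaving and the entering group aromatic, and only the one modest step available as a guide, no move beyond the usual scatter of this assay is expected, in either direction.

For compound 3 the estimated value in this assay is 2 nM, with a range of 0.7 nM to 6 nM. This estimate corresponds to an expected step of a 1.1-fold lower number from compound 2 to compound 3 (0.04 log units; within the scatter).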

Compound 3, inhibition constant: 2 nM
Compound 3: middle estimate and measured number agree at the digits printed; the range from low to high includes it.
By their numbers in this assay, from the lowest: compounds 1, 3 and 2 (each within the scatter of the next, the first and the last beyond it).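

In this assay, among these compounds, the first exchange of one aromatic ring for another on a saturated chain carbon bound to an amine nitrogen in a ring gives a 1.1-fold lower number from compound 2 to compound 3 (0.04 log units; within the scatter) and so does not separate thiophen-2-yl, with its 5 heavy atoms, from 4-methoxyphenyl, with its 8. Set against isobutyl, thiophen-2-yl gives a 2.0-fold higher number from compound 1 to compound 3 (0.30 log units; within the scatter) and stays within the scatter, whereas 4-methoxyphenyl gives a 2.2-fold higher number from compound 1 to compound 2 (0.34 log units; beyond the scatter) and lies beyond it, so the one separation on record at this position is not shared by both aromatic groups, although the two aromatic compounds themselves cannot be told apart. No supporting data bear on why these three groups read so closely.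

The compounds shown leave open whether this narrow spread holds for very different groups at the same place, such as a carboxylic acid, a primary amine or a longer chain than isobutyl. They also leave open how far the thiophen-2-yl and 4-methoxyphenyl compounds would stay together on any read-out other than this assay.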